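One Link Shorter: Estimating the Half-Life of Compound 3

The source may report more compounds than this note shows. Statements on the series, on what has been measured and on what is new or still open speak of the compounds shown alone.

In a physicochemical assay for pharmacokinetics, read by spectrophotometry, in phosphate buffer, at pH 7.4, tested at 20 uM (on this read-out lower numbers stand for a shorter-lived compound and higher numbers for a longer-lived compound), compound 1 `O=C(O)C1CCCN(CCCC=Cc2cccc(N=Nc3cccc4ccccc34)c2)C1` gives 11 h, the lowest of the two numbers recorded. Among the compounds with values here, its only neighbour is compound 2 `O=C(O)C1CCCN(CCCC=Cc2cccc(N=Nc3ccccc3)c2)C1`, which in this assay gives 288 h. Within the data shown here, the single measured step, a 26-fold higher number from compound 1 to compound 2 (1.42 log units; beyond the scatter), concerns the aromatic group on the double-bonded nitrogen and leaves the chain untouched. Compound 3 `O=C(O)C1CCCN(CCC=Cc2cccc(N=Nc3cccc4ccccc34)c2)C1` differs from compound 1 in another part of the molecule: 3-carboxypiperidin-1-yl in place of (3-carboxypiperidin-1-yl)methyl on a saturated chain carbon, two bonds along the chain from a double-bonded chain carbon. Among the measured compounds shown here, no measured step shortens the chain in this manner, so the step already known gives no guide to the size or direction of this change. With nothing to indicate a move either way, the expected change in this assay is none beyond the scatter, and the range is kept wide. Compound 3 is accordingly estimated to give 11 h in this assay, within 3.5 h to 35 h. This amounts to an expected step of no change at the digits printed from compound 1 to compound 3 (within the scatter), inside the scatter.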

Compound 3, half-life: 22 h
Compound 3: the middle estimate sits 2.0-fold (0.30 log units) below what was measured; the measured number falls inside the stated range.
By their numbers in this assay, from the lowest: compounds 1 and 3 (each within the scatter of the next); then compound 2.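

In this assay, 3-carboxypiperidin-1-yl in place of (3-carboxypiperidin-1-yl)methyl on a saturated chain carbon, two bonds along the chain from a double-bonded chain carbon, gives a 2.0-fold higher number from compound 1 to compound 3 (0.30 log units; within the scatter), so this shortening of the chain leaves the two compounds within the scatter of each other. The earlier step, a 26-fold higher number from compound 1 to compound 2 (1.42 log units; beyond the scatter), lies beyond the scatter and concerns the aromatic group on the double-bonded nitrogen, whereas this first reading of the chain, on the naphthalen-1-yl compounds, shows no difference that can be told from the scatter. No supporting measurement is available to account for either reading.

Going by these compounds, it remains open whether the shorter chain would read the same with phenyl on the double-bonded nitrogen. Also open, on these data alone, is how a longer chain, or a methyl ester in place of the carboxylic acid, would read.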